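This account rests on a few compounds, and the source may have more. Where it says the series, first, only, none or still open, it means among the compounds named here.

Of the compounds shown here, two with a shared core have been measured. In a functional assay on MCF7 cells (Homo sapiens) for cytotoxicity, read by MTT assay, with a stated time of 48 h (on this read-out higher numbers stand for weaker inhibition and lower numbers for stronger inhibition), compound 1 `C=CC(C)(O)CC[C@@H]1C(=C)CC[C@H](Br)[C@@]1(C)CCC(O)C(C)(C)Cl` gives 71500 nM. Compound 2 `C=CC(C)(O)CC[C@@H]1C(=C)CC[C@H](Br)[C@@]1(C)CCC(O)C(C)(C)O` differs from it by a hydroxy in place of chloro on a saturated chain carbon bound to three saturated chain carbons. In this assay compound 2 reaches only a limit, > 100000 nM. That comparison gives an at least 1.3-fold higher number from compound 1 to compound 2 (0.14 log units; that floor lies within the scatter); the one limit among the two values is the limit of > 100000 nM in this assay, at which 1 of the 2 values shown sits. Both compounds thus sit at the weak end of what this assay can show.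

Compound 3 `C=CC(C)(O)CC[C@@H]1C(=C)CC[C@H](Br)[C@@]1(C)CCC(=O)C(C)C` is not yet measured. Its change from compound 2 is isopropylcarbonyl in place of 1,2-dihydroxy-2-methylpropyl on a saturated chain carbon, two bonds along the chain from a saturated ring carbon. Within the data shown here, no measured step removes both oxygens from this side chain; the only step on record is an at least 1.3-fold higher number from compound 1 to compound 2 (0.14 log units; that floor lies within the scatter), which swaps a single group on that chain without a shift beyond the scatter. No direction can therefore be drawn from the data, and the expectation for compound 3 is a reading that stays near the limit. Compound 3 is estimated at 70000 nM, with a range from 15000 nM to 250000 nM. This corresponds to an expected step of an at least 1.4-fold lower number from compound 2 to compound 3 (0.15 log units; that floor lies within the scatter).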

Compound 3, half-maximal inhibitory concentration: > 100000 nM
Compound 3 was reported as a limit; the forecaster's own chance of this, stated with the estimate: 35%; middle value at least 1.4-fold (0.15 log units) away from the limit.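

In this assay compound 3 gives > 100000 nM, which is a limit of the assay and not a number, so removing both hydroxy groups from this side chain and leaving a single carbonyl with no hydrogen-bond donors does not bring the reading to a measurable value. Measured against the chloro-bearing chain, isopropylcarbonyl in place of 2-chloro-1-hydroxy-2-methylpropyl gives an at least 1.3-fold higher number from compound 1 to compound 3 (0.14 log units; that floor lies within the scatter), so this change, like the earlier swap of a single group, shows no shift beyond the scatter. The step between compound 2 and compound 3 cannot be read, because both of their results are limits: the limit of > 100000 nM in this assay, at which 2 of the 3 values shown sit.

The compounds shown leave open how far compound 2 and compound 3 really lie from compound 1, since only compound 1 has a reading that is an actual number. They also leave open whether an amine or a carboxylic acid, or a longer chain, at this place on the shared core would give a clearly lower number in this assay.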